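Swapping the triazole aryl group in a spiro-oxindole series

This account rests on a few compounds, and the source may have more. Where it says the series, first, only, none or still open, it means among the compounds named here.

Compound 1 `N#CC1=C(N)Oc2c(N)cc3nc4ccccc4nc3c2C12C(=O)N(Cc1cnnn1-c1ccc(F)cc1)c1ccccc12`: > 50000 nM
Compound 2 `N#CC1=C(N)Oc2c(N)cc3nc4ccccc4nc3c2C12C(=O)N(Cc1cnnn1-c1cccc(C(F)(F)F)c1)c1ccccc12`: 5400 nM

In a functional assay on A549 cells (Homo sapiens) for antiproliferative activity, read by MTT assay, with a stated time of 48 h (a lower number here means a stronger inhibitor, a higher number a weaker inhibitor), compound 1 gives only a limit, > 50000 nM, not a number. Compound 2 gives the only true number shown, 5400 nM. For the measured compounds named here, the single measured step, an at least 9.2-fold lower number from compound 1 to compound 2 (0.96 log units; beyond the scatter), rests on that limit (the limit of > 50000 nM in this assay, at which 1 of the 2 values shown sits), so its full size stays open. Compound 3 `CC(=O)Nc1ccc(-n2nncc2CN2C(=O)C3(C(C#N)=C(N)Oc4c(N)cc5nc6ccccc6nc5c43)c3ccccc32)cc1` carries the change (4-acetamidophenyl in place of 3-(trifluoromethyl)phenyl on an aromatic nitrogen). The same position has already moved the read-out, so a shift beyond the scatter is plausible, though its direction cannot be read from one step; compound 3 is expected near 9000 nM, between 2000 nM and 40000 nM, the step of a 1.7-fold higher number from compound 2 to compound 3 (0.22 log units; within the scatter) being the estimate.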

Compound 3, half-maximal inhibitory concentration: > 50000 nM
Compound 3 gave a limit, no number (the forecaster's own chance of this, stated with the estimate: 25%); middle value at least 5.5-fold (0.74 log units) away from the limit.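

In this assay, 4-acetamidophenyl in place of 3-(trifluoromethyl)phenyl gives an at least 9.2-fold higher number from compound 2 to compound 3 (0.96 log units; beyond the scatter). Compound 3 gives only a limit, not a number, so the full size of that step stays open, and among these three compounds only the 3-(trifluoromethyl)phenyl group gives a true number. The step between compound 1 and compound 3 cannot be read because both values are limits: the limit of > 50000 nM in this assay, at which 2 of the 3 values shown sit.

Going by these compounds, it remains open whether the group itself or its place on the phenyl ring matters more. A 4-(trifluoromethyl)phenyl or a 3-acetamidophenyl group would separate the two.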